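A Thiazole Ring in Place of 3-Bromophenyl

The source may hold more compounds than are shown below. What is called first, only, known or untested is meant among the compounds shown, and "the series" means these compounds.

In an ADME assay on L6 cells (Rattus norvegicus) for cytotoxicity, read by resazurin assay, with a stated time of 72 h (a lower number here means a stronger inhibitor, a higher number a weaker inhibitor), compound 1 `Cc1ccccc1C(O)(c1ccc(Cl)cc1)c1cccnc1` gives 82000 nM and compound 2 `OC(c1ccc(Cl)cc1)(c1cccnc1)c1cccc(Br)c1` gives 54100 nM as its value. These two values lie within the usual scatter of repeat measurements, so compound 2 stands level with compound 1 and neither can be ranked above the other.

Compound 3 `OC(c1ccc(Cl)cc1)(c1cccnc1)c1nccs1` differs from compound 2 in one place, on a saturated chain carbon bound to two aromatic carbons and an oxygen on a saturated carbon (the change: 1,3-thiazol-2-yl in place of 3-bromophenyl on a saturated chain carbon bound to two aromatic carbons and an oxygen on a saturated carbon).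

Going by the values given here, one measured step bears on this place, the swap of 2-methylphenyl for 3-bromophenyl (the step: a 1.5-fold lower number from compound 1 to compound 2 (0.18 log units; within the scatter)). That exchange of one aromatic ring for another stayed within the scatter. Among the compounds with values here, it is a thin guide, and no measured compound carries a five-membered ring there.

The step expected in this assay therefore stays within the scatter, with no firm direction (estimated as a 1.3-fold higher number from compound 2 to compound 3 (0.11 log units; within the scatter)). The value of compound 3 is expected to be 70000 nM (estimated range 30000 nM to 150000 nM).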

Compound 3, half-maximal inhibitory concentration: > 100000 nM
Compound 3 ended at the assay's limit; the forecaster's own chance of this, stated with the estimate: 15%; middle value at least 1.4-fold (0.15 log units) from the limit.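

In this assay compound 3 gives a limit and not a number, so it cannot be placed exactly beside the other compounds: (the limit of > 100000 nM in this assay, at which 1 of the 3 values shown sits). On the saturated chain carbon bound to two aromatic carbons and an oxygen, putting 1,3-thiazol-2-yl in place of 3-bromophenyl gives an at least 1.8-fold higher number from compound 2 to compound 3 (0.26 log units; that floor lies within the scatter) and putting it in place of 2-methylphenyl gives an at least 1.2-fold higher number from compound 1 to compound 3 (0.08 log units; that floor lies within the scatter) as the two readings, which bring the first five-membered aromatic ring with 2 hetero atoms to this place. Both readings are only floors that lie within the scatter, so they show no firm change, and the real size of each step has no upper end.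

The compounds shown leave open whether this place responds at all to something other than an aromatic ring, such as an amine, a carboxylic acid or a longer chain. They also leave open where compound 3 truly stands, since its limit cannot settle any ranking against the two compounds that carry six-membered rings here.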